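The compounds below may be only part of what the source reports. "The series", "measured", "known", "first", "only" and "open" are said of these compounds alone.

Working notes on the series in a functional assay on the whole organism with Mus musculus as the target; on this read-out lower numbers stand for an effect already at smaller amounts and higher numbers for an effect only at larger amounts of compound. Compound 1 `Cc1c(C)c2c(c(C)c1N)CC(C)(CBr)O2` gives 16 mg/kg. Compound 2 `COC(=O)/C=C\C1(C)Cc2c(C)c(N)c(C)c(C)c2O1` gives > 100 mg/kg, which is a limit of the assay. Compound 3 `Cc1c(C)c2c(c(C)c1NC=O)CC(C)(C)O2` gives > 100 mg/kg, also a limit and not a number, and so stands at the limit of > 100 mg/kg in this assay, at which 2 of the 3 values shown sit. Compound 4 `CCC(=O)Nc1c(C)c(C)c2c(c1C)CC(C)(C)O2` differs from it by ethyl in place of hydrogen on a carbonyl carbon, that is, formyl to propanoyl. Going by the values given here, the one measured step, an at least 6.2-fold higher number from compound 1 to compound 2 (0.79 log units; beyond the scatter), lies at another place in the molecule and gives no size for this change. The expected outcome is a step that the limit leaves unreadable from compound 3 to compound 4, with no shift beyond the scatter foreseen and the limit likely to be met again. For compound 4 the estimated value is 120 mg/kg, with an expected range of 50 mg/kg to 300 mg/kg.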

Compound 4, dose for 50% inhibition: > 100 mg/kg
Compound 4 was reported as a limit (the forecaster's own chance of this, stated with the estimate: 70%); the middle value does not contradict the limit.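

Compound 3 and compound 4 are both limits in this assay, and no step between them can be read: the limit of > 100 mg/kg in this assay, at which 3 of the 4 values shown sit.

The compounds shown leave open whether formyl and propanoyl differ at all in this assay.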